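Aminothiazole guanidine ureas: aryl change on the benzylic carbon

A few compounds are considered here, and "the series" means these few. Any claim that something is new, unique, unknown or untested is made for them only; others in the source may bear on it.

Measured so far:
compound 1, `Cc1nc(N)sc1CCCN/C(N)=N/C(=O)N[C@@H](C)c1ccccc1`: 23.4 nM
compound 2, `Cc1nc(N)sc1CCCN/C(N)=N/C(=O)NC(C)c1ccc(Cl)cc1`: 24.6 nM
compound 3, `Cc1nc(N)sc1CCCN/C(N)=N/C(=S)N[C@H](C)c1ccccc1`: 89.1 nM

All three share the aminothiazole core linked through a three-carbon chain to an acylguanidine; they differ in the aryl group on the chain carbon and in the carbonyl-to-thiocarbonyl swap. In a functional assay on Right cardiac atrium for agonist activity at histamine H2 receptor (Cavia porcellus), with a stated time of 30 min, in the presence of a further agent that is not named here (on this read-out lower numbers stand for an effect already at smaller amounts and higher numbers for an effect only at larger amounts of compound), compound 2 gives 24.6 nM, the second highest of the three numbers. Its nearest neighbour is compound 1 at 23.4 nM, a gap within the scatter, so the two cannot be ordered. Its furthest is compound 3 at 89.1 nM, which lies beyond the scatter on the higher side; compound 3 is the only thiourea in the set.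

Compound 4, `Cc1nc(N)sc1CCCN/C(N)=N/C(=O)NC(C)c1cccc(F)c1`, remains to be measured. It carries 3-fluorophenyl in place of 4-chlorophenyl on a saturated chain carbon bound to an amide-type nitrogen and a saturated chain carbon. Among the measured compounds the only comparable aryl change, from compound 1 to compound 2, leaves the read-out within the scatter, and no other step is available. A step without a clear direction, and of a size not beyond the scatter, is therefore expected in this assay; the estimated step is a 1.1-fold higher number from compound 2 to compound 4 (0.04 log units; within the scatter). For compound 4 the expected value in this assay is 27 nM, with a range from 11 nM to 65 nM.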

Compound 4, half-maximal effective concentration: 26.3 nM
Compound 4: the middle estimate sits 1.0-fold (0.01 log units) above what was measured; measured number inside the range.
By their numbers in this assay, from the lowest: compounds 1, 2 and 4 (each within the scatter of the next); then compound 3.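

In this assay, among the compounds shown here, putting 3-fluorophenyl in place of 4-chlorophenyl on a saturated chain carbon bound to an amide-type nitrogen and a saturated chain carbon gives a 1.1-fold higher number from compound 2 to compound 4 (0.03 log units; within the scatter), and this is the first step between two measured compounds that differ in one place. At this position, the exchange therefore leaves the read-out unresolved, even though the halogen and its numbered place on the phenyl ring both change, and the two changes cannot be separated, as they occur together in this single step. No measurement is available here that bears on why this exchange leaves the number within the scatter.

As far as these compounds go, it remains open whether this tolerance extends beyond halogenated phenyl groups, for example to a phenyl ring carrying a carboxylic acid or a dimethylamino group, or to a pyridyl ring in its place. From the compounds shown here alone, it is also open whether 3-fluorophenyl or 4-chlorophenyl would behave the same way in a thiourea like compound 3, and whether the separate enantiomers of compound 2 and compound 4 would give matching numbers.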